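The source may hold more compounds than are shown below. What is called first, only, known or untested is meant among the compounds shown, and "the series" means these compounds.

Measured so far in a functional assay on HCT-116 cells (Homo sapiens) for inhibition, read by fluorescence, with a stated time of 48 h (on this read-out higher numbers stand for weaker inhibition of growth and lower numbers for stronger inhibition of growth),
- compound 1 `N[C@H](C(=O)OCCCOC1(c2ccc(Cl)cc2)c2ccccc2C(=O)N1Cc1ccc(Cl)cc1)c1ccccc1` gives 12000 nM
- compound 2 `CC(=O)OCCCOC1(c2ccc(Cl)cc2)c2ccccc2C(=O)N1Cc1ccc(Cl)cc1` gives 46000 nM
- compound 3 `CC(C)[C@H](N)C(=O)OCC(C)(C)COC1(c2ccc(Cl)cc2)c2ccccc2C(=O)N1Cc1ccc(Cl)cc1` gives 11000 nM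

Compound 3 (11000 nM) and compound 1 (12000 nM) lie within the scatter of each other, and both stand below compound 2 (46000 nM).

Compound 4 `O=C1c2ccccc2C(OCCCO)(c2ccc(Cl)cc2)N1Cc1ccc(Cl)cc1` has 2-hydroxyethyl in place of 1-((((1-amino-2-methylpropyl)carbonyl)oxy)methyl)-1-methylethyl on a saturated chain carbon bound to an oxygen on a saturated carbon.

For the measured compounds named here, two measured steps bear on this, a 3.8-fold higher number from compound 1 to compound 2 (0.58 log units; beyond the scatter) and a 4.2-fold lower number from compound 2 to compound 3 (0.62 log units; beyond the scatter), both modest. Neither ends in a 2-hydroxyethyl group, so they guide the estimate only indirectly. Like compound 2, compound 4 has no amino group, so a modest rise in this assay is expected, beyond the scatter. The expected change is a 2.7-fold higher number from compound 3 to compound 4 (0.44 log units; beyond the scatter) (an estimate). The estimated value for compound 4 is 30000 nM (range 14000 nM to 70000 nM).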

Compound 4, concentration for 50% growth inhibition: 60000 nM
Compound 4: the middle estimate sits 2.0-fold (0.30 log units) below what was measured; low and high end bracket the measured number.
By their numbers in this assay, from the lowest: compounds 3 and 1 (each within the scatter of the next); then compounds 2 and 4 (each within the scatter of the next).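

In this assay, hydrogen in place of acetyl on this oxygen stays within the scatter, with a 1.3-fold higher number from compound 2 to compound 4 (0.12 log units; within the scatter), so the free alcohol and the acetyl ester cannot be told apart. Against that alcohol, both amino-bearing esters stand apart, with a 5.5-fold higher number from compound 3 to compound 4 (0.74 log units; beyond the scatter) and a 5.0-fold higher number from compound 1 to compound 4 (0.70 log units; beyond the scatter). Nothing available explains this difference. The compounds shown leave open whether the amino group alone accounts for it, and how an amide or a carboxylic acid at this position would compare.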